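Indole amide on the PLK2 core: a step from compound 1

A few compounds are considered here, and "the series" means these few. Any claim that something is new, unique, unknown or untested is made for them only; others in the source may bear on it.

Of the compounds shown here, three that share one core have been measured in an assay for inhibition of serine/threonine-protein kinase PLK2 (Homo sapiens), read by FRET and Z'-LYTE, with a stated time of 1 h; a lower number here means a stronger inhibitor, a higher number a weaker inhibitor. Compound 1 `CC[C@@H]1C(=O)N(C)c2cnc(-n3ccc4ccccc43)nc2N1C1CCCC1` carries an indole on that core and in this assay gives 355 nM, the highest of the three numbers. Among the compounds with values here, compound 2 `CCCNS(=O)(=O)c1ccc(Nc2ncc3c(n2)N(C2CCCC2)[C@H](CC)C(=O)N3C)cc1` instead bears an anilino-sulfonamide and gives 17.8 nM, and compound 3 `CC[C@@H]1C(=O)N(C)c2cnc(Nc3ccc(S(=O)(=O)NCCCO)cc3)nc2N1C1CCCC1`, with a hydroxy on the sulfonamide chain, gives 8.16 nM; the step of a 2.2-fold lower number from compound 2 to compound 3 (0.34 log units; beyond the scatter) is the only measured change at a single place. Compound 1 thus stands well above compound 2 and further still above compound 3.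

Compound 4 `CC[C@@H]1C(=O)N(C)c2cnc(-n3ccc4cc(C(=O)NC(C)C)ccc43)nc2N1C1CCCC1` differs from compound 1 by isopropylcarbamoyl in place of hydrogen on an aromatic carbon. Within the data shown here, no measured step touches the indole of compound 1, and the one measured step, a 2.2-fold lower number from compound 2 to compound 3 (0.34 log units; beyond the scatter), concerns a different attachment and a different group, so it bears on compound 4 only loosely. The two anilino-sulfonamide compounds show that a substituted aryl on this core can sit far lower than compound 1, but they do not tell how an amide on the indole behaves. A modest drop is expected for compound 4, a 2.7-fold lower number from compound 1 to compound 4 (0.44 log units; beyond the scatter), with wide uncertainty. For compound 4 the estimate in this assay is 130 nM, between 25 nM and 650 nM.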

Compound 4, half-maximal inhibitory concentration: 17.4 nM
Beside the measured number, compound 4's estimate is 7.5-fold (0.87 log units) above it; the whole stated range lies above it.
By their numbers in this assay, from the lowest: compound 3; then compounds 4 and 2 (each within the scatter of the next); then compound 1.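

In this assay, within the data shown here, isopropylcarbamoyl in place of hydrogen on an aromatic carbon of the indole gives a 20-fold lower number from compound 1 to compound 4 (1.31 log units; beyond the scatter), the first measured step at this position and a large one. It shows that this place, on the six-membered aromatic ring of the fused system, is far from silent: a single entering group of 6 heavy atoms, carrying one hydrogen-bond donor and one hydrogen-bond acceptor, moves the number well beyond the scatter, so the indole compounds are not confined to the high value of the unsubstituted parent. The data at hand offer no measurement that would account for the size of this step.

The compounds shown leave open which part of the entering group carries the step, as a plain primary carboxamide, a methyl amide, a carboxylic acid or an amide with a longer chain would separate the carbonyl and the amide hydrogen from the isopropyl. Also open, on these data alone, is whether a hydroxy on the amide chain would act here as it does on the sulfonamide chain, where it gives a 2.2-fold lower number from compound 2 to compound 3 (0.34 log units; beyond the scatter), and how the same amide would fare on the other aromatic carbons of the indole.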